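Carboxy for trifluoromethyl on the pyridin-2-yl arm

The compounds below may be only part of what the source reports. "The series", "measured", "known", "first", "only" and "open" are said of these compounds alone.

Compound 2 `FC(F)(F)c1ccc(Nc2cc3[nH]c(-c4cccc(C(F)(F)F)c4)nc3cn2)nc1` carries a 5-(trifluoromethyl)pyridin-2-yl on a nitrogen attached to the shared core. In a physicochemical assay for solubility, using the shake flask method, measured as kinetic solubility, with a stated time of 20 h, at pH 2 (a higher number here means a more soluble compound, a lower number a less soluble compound), compound 2 gives < 5000 nM, which is a limit of the assay and not a number. Compound 1 `COc1ccnc(Nc2cc3[nH]c(-c4cccc(C(F)(F)F)c4)nc3cn2)c1` has the same standing: in this assay compound 1 gives < 5000 nM, again only a limit. Going by the values given here, the single measured step, a step that the two limits leave unreadable from compound 1 to compound 2, thus has no readable size, and the limit of < 5000 nM in this assay, at which 2 of the 2 values shown sit, is all that fixes where compound 2 stands.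

Compound 3 `O=C(O)c1ccc(Nc2cc3[nH]c(-c4cccc(C(F)(F)F)c4)nc3cn2)nc1` differs from compound 2 by carboxy in place of trifluoromethyl on an aromatic carbon. Among the compounds with values here, no measured step bears on this change, since the only step in the set is unreadable. The step from compound 2 to compound 3 is therefore expected only as a rough guess, an at least 1.6-fold higher number from compound 2 to compound 3 (0.20 log units; that floor lies within the scatter), in the direction of more solubility. Compound 3 is expected near 8000 nM, within a range of 1500 nM to 50000 nM, with a fair chance that only a limit is reported once more.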

Compound 3, solubility: < 5000 nM
Compound 3 gave a limit, no number (the forecaster's own chance of this, stated with the estimate: 40%); middle value at least 1.6-fold (0.20 log units) from the limit.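

No step among compound 1, compound 2 and compound 3 can be read, as each gives a limit of the assay and not a number: the limit of < 5000 nM in this assay, at which 3 of the 3 values shown sit.

The compounds shown leave open where any of the three truly lies in this assay, and whether carboxy in place of trifluoromethyl shifts the read-out at all.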